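A few compounds are considered here, and "the series" means these few. Any claim that something is new, unique, unknown or untested is made for them only; others in the source may bear on it.

Measured so far in an assay on isolated protein for inhibition of Calpain-1 catalytic subunit (Sus scrofa), read by FRET; on this read-out higher numbers stand for weaker inhibition and lower numbers for stronger inhibition:
- compound 1 `O=C(O)/C(S)=C/c1cccc(F)c1`: 19000 nM
- compound 2 `O=C(O)/C(S)=C/c1cccc(Br)c1`: 4000 nM

Going by the values given here, compound 2 has the lower of the two numbers, and the only other measured compound, compound 1, sits above it by the step of a 4.8-fold lower number from compound 1 to compound 2 (0.68 log units; beyond the scatter), which lies beyond the scatter. The change followed here is iodo in place of bromo on an aromatic carbon, giving compound 3 `O=C(O)/C(S)=C/c1cccc(I)c1`. Among the compounds with values here, the single measured step that bears on it is a 4.8-fold lower number from compound 1 to compound 2 (0.68 log units; beyond the scatter), where one halogen replaced another on the aromatic carbon and the number fell. Continuing in that direction, a step of a 2.0-fold lower number from compound 2 to compound 3 (0.30 log units; within the scatter) is expected, probably smaller than the one measured, since no measured step here went past bromo and this rests on one comparison only. The estimate for compound 3 in this assay is 2000 nM, with a range from 800 nM to 6000 nM.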

Compound 3, half-maximal inhibitory concentration: 4300 nM
Estimate against measurement, compound 3: 2.2-fold (0.33 log units) below; low and high end bracket the measured number.
By their numbers in this assay, from the lowest: compounds 2 and 3 (each within the scatter of the next); then compound 1.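

Going from bromo to iodo at this position in this assay gives a 1.1-fold higher number from compound 2 to compound 3 (0.03 log units; within the scatter) and so no real change, which means that compound 2 and compound 3 cannot be told apart. Compared with the fluoro compound, the iodo compound shows a 4.4-fold lower number from compound 1 to compound 3 (0.65 log units; beyond the scatter) and so keeps about the same advantage as the bromo compound, which makes this a split between fluoro on one side and bromo and iodo on the other rather than a number that keeps falling along the halogens. No measurement available here explains why the number stops falling after bromo.

Where chloro would fall at this position remains open, as it could sit with fluoro or with bromo and iodo. From the compounds shown here alone, it is also open whether groups that are not halogens, such as methyl, methoxy or nitrile, could bring the number lower on this aromatic carbon.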